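A Small Ring Swap and Its Expected Effect on Cytotoxicity

This account rests on a few compounds, and the source may have more. Where it says the series, first, only, none or still open, it means among the compounds named here.

Of the compounds shown here, two built on a shared core have been tested in a functional assay on A-375 cells (Homo sapiens) for cytotoxicity, read by MTT assay, with a stated time of 48 h; a higher number here means a weaker inhibitor, a lower number a stronger inhibitor. Compound 1 `CC1(C)S[C@@H]2/C(=C\C(=O)c3ccc(C(F)(F)F)cc3)C(=O)N2[C@H]1C(=O)OC(c1ccccc1)c1ccccc1` gives 26700 nM in this assay. Compound 2 `CC1(C)[C@H](C(=O)OC(c2ccccc2)c2ccccc2)N2C(=O)/C(=C/C(=O)c3ccccc3)[C@H]2S1(=O)=O` gives 17500 nM. Compound 1 has the higher of the two numbers, but the gap to compound 2 lies within the usual scatter of repeated measurements, so the two cannot be told apart, and both count as weak inhibitors of these cells.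

Compound 3 `CC1(C)S[C@@H]2/C(=C\C(=O)c3cc(F)cc(F)c3)C(=O)N2[C@H]1C(=O)OC(c1ccccc1)c1ccccc1` has not yet been measured. It differs from compound 1 in one place: 3,5-difluorophenyl in place of 4-(trifluoromethyl)phenyl on a carbonyl carbon. Among the measured compounds shown here, nothing measured so far shows what this kind of change does on this core, since no pair of tested compounds differs only in this way. With no evidence pointing in either direction, the step expected from the measured parent, a 1.1-fold lower number from compound 1 to compound 3 (0.03 log units; within the scatter), is estimated to be none beyond the scatter. Compound 3 is therefore expected to give 25000 nM in this assay, with a likely range from 9000 nM to 70000 nM.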

Compound 3, half-maximal inhibitory concentration: 19100 nM
Compound 3: middle estimate off by 1.3-fold (0.12 log units), on the high side; the range from low to high includes it.
By their numbers in this assay, from the lowest: compounds 2, 3 and 1 (each within the scatter of the next).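

In this assay, among the compounds shown here, the change from 4-(trifluoromethyl)phenyl to 3,5-difluorophenyl on a carbonyl carbon gives a 1.4-fold lower number from compound 1 to compound 3 (0.15 log units; within the scatter) and this is the first pair on the shared core to differ in one place only. At this position, then, one fluorine-bearing aromatic ring can stand in for another, and the two compounds still cannot be told apart in this cell test. No outside evidence bears on this result, so nothing can be said about what lies behind it.

As far as these compounds go, whether any group on this carbonyl carbon can move the number beyond the scatter remains open, as both rings in this pair are fluorine-bearing phenyl rings, and a pyridine ring, or a phenyl ring carrying an amine or a carboxylic acid, would be a different kind of test. Compound 2 differs from compound 1 and compound 3 in more than one place, so it cannot show what the ring on this carbonyl carbon does on its own.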